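The source may hold more compounds than are shown below. What is called first, only, known or untested is meant among the compounds shown, and "the series" means these compounds.

Compound 1, `c1ccc(/N=c2\ssnc2-c2ccccc2)cc1`: in a functional assay on MDA-MB-231 cells (Homo sapiens) for antiproliferative activity, read by MTT assay, with a stated time of 72 h (a higher number here means a weaker inhibitor of growth, a lower number a stronger inhibitor of growth), compound 1 gives > 10000 nM, a limit of the assay.
Compound 2, `O=[N+]([O-])c1ccc(-c2nss/c2=N\c2ccccc2)cc1`: in this assay compound 2 gives > 10000 nM, again a limit.

Compound 2 therefore stands at a limit only, with no number behind it. Both values shown sit at that same limit (the limit of > 10000 nM in this assay, at which 2 of the 2 values shown sit). Among the compounds with values here, the one measured step, a step that the two limits leave unreadable from compound 1 to compound 2, is a change on an aromatic carbon, and its size cannot be read; both of its ends are limits.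

Compound 3, `Fc1ccc(-c2nss/c2=N\c2ccccc2)cc1`, differs from compound 2 by fluoro in place of nitro on an aromatic carbon. Within the data shown here, the only measured step that bears on this position is a step that the two limits leave unreadable from compound 1 to compound 2, and it gives no size in either direction. With the unsubstituted compound 1 and the nitro-bearing compound 2 both at the limit, nothing in the data points to a readable gain for the fluoro compound. Compound 3 is therefore expected to sit at the limit as well, with an estimated value of 20000 nM, its range running from 8000 nM to 100000 nM. The expected step from compound 2 to compound 3 is a step that the limit leaves unreadable from compound 2 to compound 3, that is, no change beyond the scatter.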

Compound 3, concentration for 50% growth inhibition: > 10000 nM
Compound 3: a limit, no number; the forecaster's own chance of this, stated with the estimate: 85%; the middle value is on the limit's open side.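

No step can be read from compound 1 or compound 2 to compound 3, and all three compounds stand at one limit: the limit of > 10000 nM in this assay, at which 3 of the 3 values shown sit. The compounds shown leave open whether hydrogen, nitro and fluoro on this aromatic carbon differ at all in this assay, and how strongly any of the three inhibits growth.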